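Nitro-to-cyano swap on the benzamide of compound 3

A few compounds are considered here, and "the series" means these few. Any claim that something is new, unique, unknown or untested is made for them only; others in the source may bear on it.

Measured compounds in an assay on SK-BR-3 cells for inhibition of Aromatase (Homo sapiens); a lower number here means a stronger inhibitor, a higher number a weaker inhibitor:
Compound 1 `CC(C)c1ccc(COc2cc([N+](=O)[O-])ccc2NS(C)(=O)=O)cc1` gives 7450 nM.
Compound 2 `CS(=O)(=O)Nc1ccc([N+](=O)[O-])cc1OCc1ccc(Cl)cc1` gives 290 nM.
Compound 3 `O=C(Nc1ccc([N+](=O)[O-])cc1OCc1ccccc1)c1ccc([N+](=O)[O-])cc1` gives > 25000 nM.

Compound 3 stands at the limit of this assay; its value the limit of > 25000 nM in this assay, at which 1 of the 3 values shown sits, is a limit and not a number. Among the three, compounds 1 and 2 carry numbers, compound 3 does not.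

Compound 4 `N#Cc1ccc(C(=O)Nc2ccc([N+](=O)[O-])cc2OCc2ccccc2)cc1` differs from compound 3 by cyano in place of nitro on an aromatic carbon. For the measured compounds named here, the one measured step, a 26-fold lower number from compound 1 to compound 2 (1.41 log units; beyond the scatter), concerns a substituent on the benzyl ether and not the benzamide, so it does not bear directly on this change. With compound 3 sitting at a limit, compound 4 is expected to remain weak in this assay, and a step of a number no higher from compound 3 to compound 4 (the limit leaves the size open) is estimated only loosely. Compound 4 is expected near 25000 nM, within 5000 nM to 100000 nM.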

Compound 4, half-maximal inhibitory concentration: > 25000 nM
Compound 4: a limit, no number (the forecaster's own chance of this, stated with the estimate: 60%); the middle value lies on the limit itself.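

No step from compound 3 to compound 4 can be read in this assay, because both values are limits and not numbers: the limit of > 25000 nM in this assay, at which 2 of the 4 values shown sit.

The compounds shown leave open whether cyano in place of nitro changes the number at all on this core.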